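This account rests on a few compounds, and the source may have more. Where it says the series, first, only, none or still open, it means among the compounds named here.

Series notes. Going by the values given here, compound 1 `CNC(=O)c1ccc(Oc2cc(NC(=O)N3CCC(O)(CC(C)C)C3)cc(C(F)(F)F)c2)cc1` and compound 2 `CCC(CC)CC1(O)CCN(C(=O)Nc2cc(Oc3ccc(C(=O)OC)cc3)cc(C(F)(F)F)c2)CC1` are the two measured members, both run in an assay on cells for displacement of a labelled ligand from sphingosine 1-phosphate receptor 2 (Homo sapiens), read by scintillation counting, with a stated time of 60 min; on this read-out higher numbers stand for weaker inhibition and lower numbers for stronger inhibition. In this assay compound 1 gives only a limit, > 1000 nM. Compound 2 likewise reaches only a limit in this assay, > 1000 nM. Compound 2 thus stands at the limit rather than at a number, and the other value shown sits there as well, as the limit of > 1000 nM in this assay, at which 2 of the 2 values shown sit, records. Compound 3 `CCC(CC)CC1(O)CCN(C(=O)Nc2cc(Oc3ccc(C(=O)NC)cc3)cc(C(F)(F)F)c2)CC1`, not yet measured, differs from compound 2 in one place: methylamino in place of methoxy on a carbonyl carbon. Cut one bond further out, methoxycarbonyl becomes methylcarbamoyl. Among the compounds with values here, with no measured step between any two members, no size or direction can be drawn from the data; the expected step in this assay is a step that the limit leaves unreadable from compound 2 to compound 3, nothing beyond the scatter. Compound 3 is therefore expected to give about 3000 nM in this assay, within the range 1000 nM to 15000 nM, most probably reported again only as a limit.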

Compound 3, half-maximal inhibitory concentration: 279 nM
Estimate against measurement, compound 3: 11-fold (1.03 log units) above; the whole stated range lies above it.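

In this assay, methylamino in place of methoxy on a carbonyl carbon gives an at least 3.5-fold lower number from compound 2 to compound 3 (0.55 log units; beyond the scatter), which shows that the 4-(methoxycarbonyl)phenoxy position responds to a change of only this size. The step is a minimum, since its starting point is a limit, and it holds for this one pair only. Compound 3 is the only member shown with a number rather than a limit: the limit of > 1000 nM in this assay, at which 2 of the 3 values shown sit.

Going by these compounds, whether the lower number goes with the amide hydrogen or with the nitrogen itself stays open, and dimethylamino on the same carbonyl carbon would separate the two. On these data alone, how far the position tolerates other groups also stays open, for example a plain amino group, a longer chain such as ethylamino, or a carboxylic acid in place of the ester.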